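The source may report more compounds than this note shows. Statements on the series, on what has been measured and on what is new or still open speak of the compounds shown alone.

Two compounds share one core and differ only in the length of the saturated chain on the ester. Compound 1 `CCCCCCCCOC(=O)CCC(=O)N1CCN(CCCOc2cc3c(Nc4ccc(F)c(Cl)c4)ncnc3cc2OC)CC1` in a functional assay on A549 cells (Homo sapiens) for cytotoxicity, read by MTT assay, with a stated time of 24 h, tested at 20 uM (a lower number here means a stronger effect, a higher number a weaker effect of the compound at the concentration tested), gives 80%. Compound 2 `CCCCCCCCCCCCOC(=O)CCC(=O)N1CCN(CCCOc2cc3c(Nc4ccc(F)c(Cl)c4)ncnc3cc2OC)CC1` in this assay gives 86.8%. The single step that separates them, a number 6.8 percentage points higher from compound 1 to compound 2 (within the scatter), is within the scatter, so on the numbers shown compound 2 cannot be told apart from compound 1, and nothing beyond the scatter has yet been seen for lengthening this chain.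

Compound 3 `CCCCCCCCCCCCCCOC(=O)CCC(=O)N1CCN(CCCOc2cc3c(Nc4ccc(F)c(Cl)c4)ncnc3cc2OC)CC1` continues the same series: it differs from compound 2 by ethyl in place of hydrogen on a saturated chain carbon, ten or more bonds along the chain from an oxygen next to a carbonyl group. Among the measured compounds shown here, the only step that bears on it is a number 6.8 percentage points higher from compound 1 to compound 2 (within the scatter), a change of the same kind on the same chain that stayed within the scatter. Compound 3 is therefore expected to show a step of a number 1.2 percentage points higher from compound 2 to compound 3 (within the scatter) in this assay, nothing beyond the scatter in either direction. Compound 3 is estimated at 88%, with a range from 74% to 100%.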

Compound 3, a percentage reported as activity, at one concentration (the size of the read-out at that concentration, not a potency): 92.3%
Compound 3: middle estimate off by 4.3 percentage points, on the low side; the range from low to high includes it.
By their numbers in this assay, from the lowest: compounds 1, 2 and 3 (each within the scatter of the next, the first and the last beyond it).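

In this assay, ethyl in place of hydrogen on a saturated chain carbon, ten or more bonds along the chain from an oxygen next to a carbonyl group, gives a number 5.5 percentage points higher from compound 2 to compound 3 (within the scatter), so this single step again stays within the scatter. The result does, however, give the first difference beyond the scatter on this chain: the whole change, hexyl in place of hydrogen, gives a number 12.3 percentage points higher from compound 1 to compound 3 (beyond the scatter), a modest weakening of the effect at the concentration tested, while compound 2 cannot be told apart from either end. No measurement offered here accounts for this difference.

From the compounds shown here alone, it remains open how a chain shorter than that of compound 1 or longer than that of compound 3 would read in this assay. The same holds for a carboxylic acid or an amine at the end of the chain.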